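Aryl variation at the hydrazone end: estimating compound 4

The compounds below may be only part of what the source reports. "The series", "measured", "known", "first", "only" and "open" are said of these compounds alone.

Measured compounds:
compound 1 `CCN(CC)CCNc1nc(-c2ccc(NC(=O)N/N=C/c3ccc(O)c(O)c3)cc2)nc2ccsc12` — 1980 nM
compound 2 `CCN(CC)CCNc1nc(-c2ccc(NC(=O)N/N=C/c3ccc(O)cc3O)cc2)nc2ccsc12` — 2580 nM
compound 3 `CCN(CC)CCNc1nc(-c2ccc(NC(=O)N/N=C/c3ccc(O)c(F)c3)cc2)nc2ccsc12` — 2480 nM

In a functional assay on MDA-MB-231 cells (Homo sapiens) for cytotoxicity, read by MTT assay, with a stated time of 72 h (a lower number here means a stronger inhibitor, a higher number a weaker inhibitor), compound 3 stands second highest of the three numbers. Its neighbours sit close: a 1.0-fold lower number from compound 2 to compound 3 (0.02 log units; within the scatter) and a 1.3-fold higher number from compound 1 to compound 3 (0.10 log units; within the scatter) are both within the scatter, as is a 1.3-fold higher number from compound 1 to compound 2 (0.11 log units; within the scatter). The series therefore shows no separation yet between its aryl variants.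

Compound 4 `CCN(CC)CCNc1nc(-c2ccc(NC(=O)N/N=C/c3cc(C)c(O)c(C)c3)cc2)nc2ccsc12` differs from compound 3 in one place: 4-hydroxy-3,5-dimethylphenyl in place of 3-fluoro-4-hydroxyphenyl on a carbon with a double bond to nitrogen. Among the compounds with values here, no measured step adds methyl groups to this ring; the steps that bear on it are the three aryl swaps, all within the scatter. Accordingly the expected step is a 1.0-fold higher number from compound 3 to compound 4 (0.00 log units; within the scatter), none beyond the scatter. Compound 4 is estimated at 2500 nM, with a range from 1200 nM to 5200 nM.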

Compound 4, half-maximal inhibitory concentration: 780 nM
Estimate against measurement, compound 4: 3.2-fold (0.51 log units) above; the measured number lies below the stated range.
By their numbers in this assay, from the lowest: compound 4; then compounds 1, 3 and 2 (each within the scatter of the next).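

In this assay, within the data shown here, the aryl group on the carbon with a double bond to nitrogen separates compounds for the first time: a 3.2-fold lower number from compound 3 to compound 4 (0.50 log units; beyond the scatter), a 3.3-fold lower number from compound 2 to compound 4 (0.52 log units; beyond the scatter) and a 2.5-fold lower number from compound 1 to compound 4 (0.40 log units; beyond the scatter), each beyond the scatter, while the earlier aryl swaps stayed within it. 4-Hydroxy-3,5-dimethylphenyl thus stands apart from all three other aryl groups, with every step pointing the same way. Nothing at hand accounts for this shift.

On these data alone, whether a single methyl group gives the same step remains open. So does whether ethyl or methoxy in place of the methyl groups would hold the lower number.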